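The source may hold more compounds than are shown below. What is called first, only, known or untested is meant among the compounds shown, and "the series" means these compounds.

Measured so far in a functional assay on DLD-1 cells (Homo sapiens) for cytotoxicity, read by MTT assay, with a stated time of 48 h; on this read-out lower numbers stand for stronger inhibition and higher numbers for weaker inhibition:
compound 1, `Cc1ccc2nc(Cl)c(/C=N/n3cc(-c4ccccc4)nc3N)cc2c1`, gives 8790 nM
compound 2, `COc1ccc(-c2cn(/N=C/c3cc4cc(C)ccc4nc3Cl)c(N)n2)cc1`, gives 25700 nM

Within the data shown here, compound 2 gives the highest of the two numbers; the nearest is compound 1, and the one measured step, a 2.9-fold higher number from compound 1 to compound 2 (0.47 log units; beyond the scatter), lies beyond the scatter. Compound 3, `Cc1ccc2nc(Cl)c(/C=N/n3cc(-c4ccc(Cl)cc4)nc3N)cc2c1`, carries the change (chloro in place of methoxy on an aromatic carbon). Among the measured compounds shown here, only that single step bears on it: it shows that taking the methoxy away from compound 2 should move the number back toward that of compound 1, while the chloro that enters has no measured precedent here. A drop of about a 2.6-fold lower number from compound 2 to compound 3 (0.41 log units; beyond the scatter) is therefore expected in this assay, and compound 3 is estimated at 10000 nM, within 4000 nM to 30000 nM.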

Compound 3, half-maximal inhibitory concentration: 38900 nM
For compound 3 the middle estimate is 3.9-fold (0.59 log units) below the measured one; the measured number lies above the stated range.
By their numbers in this assay, from the lowest: compound 1; then compounds 2 and 3 (each within the scatter of the next).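

In this assay, chloro and methoxy at this position are not told apart: the step to chloro, a 1.5-fold higher number from compound 2 to compound 3 (0.18 log units; within the scatter), lies within the scatter. Chloro in place of hydrogen gives a 4.4-fold higher number from compound 1 to compound 3 (0.65 log units; beyond the scatter), beyond the scatter, so both substituents shown at this position go with weaker inhibition than the hydrogen of compound 1. From the compounds shown here alone, whether an amine or a carboxylic acid on this aromatic carbon would stay near compound 1 or go with a higher number remains open. No evidence on the cause of these differences is available.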